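From cyclohexyl to 1-phenylethyl on an amine nitrogen

The source may hold more compounds than are shown below. What is called first, only, known or untested is meant among the compounds shown, and "the series" means these compounds.

Measured in a functional assay on SK-BR-3 cells (Homo sapiens) for antiproliferative activity; a higher number here means a weaker inhibitor, a lower number a stronger inhibitor:
Compound 1 `CC(C)=CCc1cc(C(=O)Nc2cc3ccc(OCCCNCC(C)C)c(C)c3oc2=O)ccc1O`: 1030 nM
Compound 2 `CC(C)=CCc1cc(C(=O)Nc2cc3ccc(OCCCNC4CCCCC4)c(C)c3oc2=O)ccc1O`: 660 nM

Among the two measured compounds, compound 2, at 660 nM, lies within the scatter of compound 1. Compound 3 `CC(C)=CCc1cc(C(=O)Nc2cc3ccc(OCCCN[C@H](C)c4ccccc4)c(C)c3oc2=O)ccc1O` carries 1-phenylethyl in place of cyclohexyl on an amine nitrogen. For the measured compounds named here, the only measured step at that nitrogen, a 1.6-fold lower number from compound 1 to compound 2 (0.19 log units; within the scatter), put cyclohexyl in place of isobutyl, so no change beyond the scatter is expected in this assay. Going by the values given here, no compound with a six-membered aromatic ring on that nitrogen has been measured, so the range is kept wide. The expected step is a 1.2-fold higher number from compound 2 to compound 3 (0.08 log units; within the scatter). Compound 3 is estimated at 800 nM, with an expected range of 300 nM to 2000 nM.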

Compound 3, half-maximal inhibitory concentration: 1000 nM
Compound 3: middle estimate off by 1.3-fold (0.10 log units), on the low side; the measured number falls inside the stated range.
By their numbers in this assay, from the lowest: compounds 2, 3 and 1 (each within the scatter of the next).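

In this assay, moving to an aromatic ring on the amine nitrogen gives a 1.5-fold higher number from compound 2 to compound 3 (0.18 log units; within the scatter), and replacing the open-chain isobutyl with 1-phenylethyl gives a 1.0-fold lower number from compound 1 to compound 3 (0.01 log units; within the scatter). The three substituents on this nitrogen therefore cannot be told apart in this assay, whether the group is an open chain, a non-aromatic ring or an aromatic ring with a defined stereocentre. No evidence is available that would explain this result.

As far as these compounds go, it remains open whether the mirror-image form of 1-phenylethyl would differ from compound 3. From the compounds shown here alone, whether a benzyl group or a carboxylic acid on this substituent would move the number beyond the scatter also remains open.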